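A few compounds are considered here, and "the series" means these few. Any claim that something is new, unique, unknown or untested is made for them only; others in the source may bear on it.

Measured so far:

Compound 1, `CC(=O)Nc1ccc2nc(NC(=O)C3CCCCC3)sc2c1`: 2.7 ug/mL
Compound 2, `CC(C)CC(=O)Nc1nc2ccc(NC(=O)c3c(Cl)cccc3Cl)cc2s1`: 0.012 ug/mL

Among the compounds with values here, in a functional assay on WI-38 VA13 cells (Homo sapiens) for cytotoxicity (a higher number here means that more compound is needed for the effect, a lower number that less compound is needed), compound 2 gives 0.012 ug/mL, the lowest of the two numbers known here. Within the data shown here, its only neighbour, compound 1, gives 2.7 ug/mL, a far higher number, well beyond the usual scatter, so compound 2 needs much less material for the effect than compound 1 does. Among the measured compounds shown here, both compounds share the same core and differ in more than one place, so no single step between them can be read off.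

Compound 3, `COc1cccc(Nc2nc3ccc(NC(=O)c4c(Cl)cccc4Cl)cc3s2)c1`, has not yet been measured in this assay. It is compound 2 with one change: 3-methoxyphenyl in place of isobutylcarbonyl on a nitrogen on an aromatic ring. Nothing measured here shows what this kind of change does, so the expectation rests on compound 2 alone, with a modest loss allowed for. Compound 3 is expected to give about 0.1 ug/mL, somewhere between 0.01 ug/mL and 1 ug/mL, an expected step of an 8.3-fold higher number from compound 2 to compound 3 (0.92 log units; beyond the scatter).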

Compound 3, half-maximal effective concentration: > 7.2 ug/mL
Compound 3: a limit, no number; the forecaster's own chance of this, stated with the estimate: 5%; middle value at least 72-fold (1.85 log units) away from the limit.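

In this assay, putting 3-methoxyphenyl in place of isobutylcarbonyl on this nitrogen gives an at least 600-fold higher number from compound 2 to compound 3 (2.77 log units; beyond the scatter), so much more compound is needed for the effect after this single change. The earlier compounds shown here differ in more than one place and could not show this, whereas this step ties a large change to one group on the nitrogen, with the rest of the molecule unchanged. The value for compound 3 is a limit and not a number, so the step gives only a minimum size: the limit of > 7.2 ug/mL in this assay, at which 1 of the 3 values shown sits.

The change removes the carbonyl and brings in an aromatic ring in a single move, and the compounds shown do not separate these two parts. As far as these compounds go, what a benzoyl group on this nitrogen, which holds both a carbonyl and an aromatic ring, would do remains open.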